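Swapping the Fluorine for a Methyl on the Acid Chain

A few compounds are considered here, and "the series" means these few. Any claim that something is new, unique, unknown or untested is made for them only; others in the source may bear on it.

Compound 2 `Cc1cccc(C)c1-c1cccc(COc2ccc(CC(F)C(=O)O)cn2)c1` gives 8.6 nM in a functional assay on CHO cells for agonist activity at Free fatty acid receptor 1 (Homo sapiens), read by calcium flux (a higher number here means that more compound is needed for the effect, a lower number that less compound is needed), and stands at the lower of the two measured numbers; compound 1 `Cc1cc(CCC(=O)O)cnc1OCc1cccc(-c2c(C)cccc2C)c1` gives 2500 nM, a gap well beyond the scatter. Compound 3 `Cc1cccc(C)c1-c1cccc(COc2ccc(C(C)CC(=O)O)cn2)c1` is not yet measured. It differs from compound 2 by 1-(carboxymethyl)ethyl in place of 2-carboxy-2-fluoroethyl on an aromatic carbon. Among the compounds with values here, no measured pair shows a change of this kind, so the expectation rests on the change itself. A modest rise, a 3.5-fold higher number from compound 2 to compound 3 (0.54 log units; beyond the scatter), is expected, not far beyond the scatter. Compound 3 is therefore expected to give 30 nM, with a range from 8 nM to 150 nM.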

Compound 3, half-maximal effective concentration in the Free fatty acid receptor 1 assay: 10 nM
Compound 3: the middle estimate sits 3.0-fold (0.48 log units) above what was measured; measured number inside the range.
By their numbers in the Free fatty acid receptor 1 assay, from the lowest: compounds 2 and 3 (each within the scatter of the next); then compound 1.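

In the Free fatty acid receptor 1 assay compound 2 gives 8.6 nM and compound 3 gives 10 nM; 1-(carboxymethyl)ethyl in place of 2-carboxy-2-fluoroethyl gives a 1.2-fold higher number from compound 2 to compound 3 (0.07 log units; within the scatter). At this place on the ring, then, the fluorine is not needed to keep the number as low as that of compound 2, and the acid chain can be rearranged without a readable loss. Nothing available explains why this change is tolerated. In a physicochemical assay for lipophilicity, at pH 7.4 (a lower number here means a more polar compound, a higher number a more lipophilic compound), compound 3 gives 3.3, while the entry for compound 2 is "not determined" (no result reported), and no comparison between the two can be read there. From the compounds shown here alone, whether a longer chain or a hydroxyl group on the 1-(carboxymethyl)ethyl would keep this number remains open.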